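Extending the Acid-Bearing Chain on the Shared Core

A few compounds are considered here, and "the series" means these few. Any claim that something is new, unique, unknown or untested is made for them only; others in the source may bear on it.

Compound 1 `CCC(CC)(c1ccc(OCC(=O)O)c(C)c1)c1ccc(OCC(O)C(C)(C)C)c(OCC(O)C(C)(C)C)c1` gives 10% in an assay on cells for binding affinity to vitamin D3 receptor (Homo sapiens), read by fluorescence, tested at 1 uM; on this read-out higher numbers stand for more inhibition at the one concentration tested (going by the name of the read-out) and lower numbers for less inhibition.
Compound 2 `CCC(CC)(c1ccc(OCCCC(=O)O)c(C)c1)c1ccc(OCC(O)C(C)(C)C)c(OCC(O)C(C)(C)C)c1` gives 14% in this assay.

Compound 2 stands highest of the two numbers, with compound 1 nearest, but the step of a number 4 percentage points higher from compound 1 to compound 2 (within the scatter) lies within the scatter, so no order between the two can be claimed. Compound 3 `CCC(CC)(c1ccc(OCCCCCC(=O)O)c(C)c1)c1ccc(OCC(O)C(C)(C)C)c(OCC(O)C(C)(C)C)c1` has not yet been measured. It differs from compound 2 in 2-carboxyethyl in place of carboxy on a saturated chain carbon, three bonds along the chain from an oxygen on an aromatic ring. Within the data shown here, the only measured step that bears on this change is the one from compound 1 to compound 2, a number 4 percentage points higher from compound 1 to compound 2 (within the scatter), which brought the same exchange, 2-carboxyethyl in place of carboxy, on the same chain and stayed within the scatter. Because a number 4 percentage points higher from compound 1 to compound 2 (within the scatter) gave no movement beyond the scatter, compound 3 is expected to show no step beyond it either in this assay. The step of a number 2 percentage points higher from compound 2 to compound 3 (within the scatter) is the expected outcome. Compound 3 is therefore estimated at 16%, with a range from 4% to 30%.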

Compound 3, a percentage reported as inhibition, at one concentration (the size of the read-out at that concentration, not a potency): "not active" (no number reported)
No number was reported for compound 3; no gap can be computed for the estimate.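

Among these compounds, compound 3 came back from this assay as "not active" with no number, so no step from compound 2 to compound 3 can be read. No measured property in the data speaks to this result. The compounds shown leave open how compound 3 stands numerically against compound 2 and compound 1 on the extended acid-bearing chain.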